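Methoxy to phenoxy at the end of the amide chain

The source may report more compounds than this note shows. Statements on the series, on what has been measured and on what is new or still open speak of the compounds shown alone.

Three compounds share one core and differ only in the group on the amide-type nitrogen. In an assay on isolated protein for displacement of a labelled ligand from Adrenergic receptor alpha-1 (Rattus norvegicus) (on this read-out higher numbers stand for weaker inhibition and lower numbers for stronger inhibition), compound 1 `COc1cc2nc(N3CCC(C(=O)NC4CCCC4)CC3)nc(N)c2cc1OC` gives 0.63 nM, compound 2 `COc1cc2nc(N3CCC(C(=O)NCCO)CC3)nc(N)c2cc1OC` gives 1.73 nM, and compound 3 `COCCNC(=O)C1CCN(c2nc(N)c3cc(OC)c(OC)cc3n2)CC1` gives 1.13 nM. Compound 3 sits second highest of the three numbers, yet its steps to both other compounds, a 1.5-fold lower number from compound 2 to compound 3 (0.18 log units; within the scatter) and a 1.8-fold higher number from compound 1 to compound 3 (0.25 log units; within the scatter), stay within the scatter; only a 2.7-fold higher number from compound 1 to compound 2 (0.44 log units; beyond the scatter) reaches beyond it. Compound 4 `COc1cc2nc(N3CCC(C(=O)NCCOc4ccccc4)CC3)nc(N)c2cc1OC` carries the change (phenyl in place of methyl on an oxygen on a saturated carbon), so the 2-methoxyethyl becomes a 2-phenoxyethyl. The step that touches this same oxygen, a 1.5-fold lower number from compound 2 to compound 3 (0.18 log units; within the scatter), was small, and the cyclopentyl of compound 1, which also brings a ring, gave a number within the scatter of compound 3 (a 1.8-fold higher number from compound 1 to compound 3 (0.25 log units; within the scatter)). A step within the scatter is therefore expected in this assay, if anything toward a slightly lower number, a 1.4-fold lower number from compound 3 to compound 4 (0.15 log units; within the scatter). Compound 4 is estimated at 0.8 nM, with a range from 0.3 nM to 2.5 nM.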

Compound 4, inhibition constant: 0.42 nM
The estimate for compound 4 lay 1.9-fold (0.28 log units) above the measured number; the measured number falls inside the stated range.
By their numbers in this assay, from the lowest: compounds 4, 1, 3 and 2 (each within the scatter of the next, the first and the last beyond it).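

Going by these compounds alone, putting a phenyl on this oxygen matters more in this assay than the earlier compounds showed: replacing its methyl gives a step beyond the scatter (a 2.7-fold lower number from compound 3 to compound 4 (0.43 log units; beyond the scatter)), whereas the step from hydrogen to methyl on the same oxygen stayed within it. Compared with the free hydroxyl, the phenyl gives the largest step among these compounds (a 4.1-fold lower number from compound 2 to compound 4 (0.61 log units; beyond the scatter)), so this position accepts a six-membered aromatic ring at the end of the chain. The 2-phenoxyethyl and cyclopentyl groups on the amide-type nitrogen cannot be told apart here (a 1.5-fold lower number from compound 1 to compound 4 (0.18 log units; within the scatter)), although they differ in shape of chain and ring. Nothing given here bears on the reason for these steps. Still open, as far as these compounds go, is whether a benzyl group on this oxygen, a chlorine on the phenyl or a longer chain before the oxygen would keep the number this low.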